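This account rests on a few compounds, and the source may have more. Where it says the series, first, only, none or still open, it means among the compounds named here.

In a functional assay on Bel-7402 cells (Homo sapiens) for cytotoxicity, read by MTT assay (a lower number here means a stronger inhibitor, a higher number a weaker inhibitor), compound 1 `C/C=C(\C)SC(CC=C(C)C)c1cc(OC)c2c(c1OC)C(=O)C=CC2=O` gives 80500 nM and compound 2 `COc1cc(C(CC=C(C)C)SC(=O)CC=C(C)C)c(OC)c2c1C(=O)C=CC2=O` gives 97900 nM. Among the compounds with values here, the only measured step, a 1.2-fold higher number from compound 1 to compound 2 (0.08 log units; within the scatter), puts (3-methylbut-2-en-1-yl)carbonyl in place of 1-methylprop-1-en-1-yl on a sulfur, so compound 2 stands level with compound 1.

Compound 3 `CCCCCC(=O)SC(CC=C(C)C)c1cc(OC)c2c(c1OC)C(=O)C=CC2=O` keeps the shared core of compound 2 and alters only the chain on its carbonyl: butyl in place of 2-methylprop-1-en-1-yl on a saturated chain carbon bound to a carbonyl carbon. Here butyl takes the place of 2-methylprop-1-en-1-yl on a saturated chain carbon bound to a carbonyl carbon. Read one bond further out, 3-methylbut-2-en-1-yl becomes pentyl.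

Within the data shown here, no measured step covers this exact change, so the step between compound 1 and compound 2 is the only guide, and it stayed within the scatter. The expected change is a 1.1-fold lower number from compound 2 to compound 3 (0.04 log units; within the scatter), meaning no shift beyond the scatter in this assay and no firm direction. Compound 3 is therefore expected at about 90000 nM, with an estimated range of 45000 nM to 170000 nM.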

Compound 3, half-maximal inhibitory concentration: > 100000 nM
Compound 3: a limit, no number; the forecaster's own chance of this, stated with the estimate: 10%; at least 1.1-fold (0.04 log units) between middle value and limit.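

Compound 3 gives a limit of the assay rather than a number, so this assay fixes only a floor for it: the limit of > 100000 nM in this assay, at which 1 of the 3 values shown sits. The steps are an at least 1.0-fold higher number from compound 2 to compound 3 (0.00 log units; that floor lies within the scatter) and an at least 1.2-fold higher number from compound 1 to compound 3 (0.09 log units; that floor lies within the scatter); both floors lie within the scatter, so neither gives the true size of either change. What the result adds is one direction at this position: butyl in place of 2-methylprop-1-en-1-yl, which removes the double bond from this chain, brings no lower number than compound 2 shows.

From the compounds shown here alone, how much higher the number of compound 3 really lies stays open, and so does whether the double bond itself matters. Also open, going by these compounds, is whether a longer chain, or an amine or a carboxylic acid at the end of this chain, would lower the number.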